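Swapping Nitro for Amino in Compound 3

A few compounds are considered here, and "the series" means these few. Any claim that something is new, unique, unknown or untested is made for them only; others in the source may bear on it.

In a functional assay on CCRF-CEM cells (Homo sapiens) for antiproliferative activity, with a stated time of 72 h (a higher number here means a weaker inhibitor, a lower number a stronger inhibitor), compound 3 (`COc1ccc(-c2c(Cl)sc(=O)n2-c2cc(OC)c(OC)c(OC)c2)cc1[N+](=O)[O-]`) gives 7500 nM and compound 2 (`COc1ccc(-c2csc(=O)n2-c2cc(OC)c(OC)c(OC)c2)cc1[N+](=O)[O-]`) gives 8200 nM here, level within the scatter. For compound 1 (`COc1ccc(-c2c(Cl)sc(=O)n2-c2cc(OC)c(OC)c(OC)c2)cc1`), this assay gives only a limit: > 20000 nM and no true number.

Compound 4 (`COc1ccc(-c2c(Cl)sc(=O)n2-c2cc(OC)c(OC)c(OC)c2)cc1N`) differs from compound 3 by amino in place of nitro on an aromatic carbon. For the measured compounds named here, two measured steps bear on this. Adding nitro gave an at least 2.6-fold lower number from compound 1 to compound 3 (0.42 log units; beyond the scatter) in that ring, so this position can shift the result. Adding chloro gave a 1.1-fold lower number from compound 2 to compound 3 (0.04 log units; within the scatter) and offers little guidance. Going by the values given here, no measured step swaps nitro for amino, so direction and size remain uncertain, with a modest fall tentatively expected. In this assay the expected change is a 1.9-fold lower number from compound 3 to compound 4 (0.27 log units; within the scatter) at this stage. Compound 4 is therefore estimated at 4000 nM (range 300 nM to 20000 nM).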

Compound 4, half-maximal inhibitory concentration: 120 nM
Beside the measured number, compound 4's estimate is 33-fold (1.52 log units) above it; the measured number lies below the stated range.
By their numbers in this assay, from the lowest: compound 4; then compounds 3 and 2 (each within the scatter of the next). At a limit, above all of these: compound 1.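

Amino in place of nitro gives a 63-fold lower number from compound 3 to compound 4 (1.80 log units; beyond the scatter) at this ortho-to-methoxy carbon, so the choice of group here matters far more than the earlier nitro step could show. Amino in place of hydrogen gives an at least 160-fold lower number from compound 1 to compound 4 (2.22 log units; beyond the scatter) at the same carbon, a size that rests on a limit for compound 1: the limit of > 20000 nM in this assay, at which 1 of the 4 values shown sits.

Going by these compounds, it remains open whether a dimethylamino group, an acetamide or a hydroxyl group at this carbon would keep the low number. Whether the chloro group matters alongside the amino group also stays unsettled.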